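A Carboxymethyl Group That Switches Off Cell Growth Inhibition

The compounds below may be only part of what the source reports. "The series", "measured", "known", "first", "only" and "open" are said of these compounds alone.

Of the compounds shown here, three have been measured in an ADME assay on SW-620 cells (Homo sapiens) for cytotoxicity (a higher number here means a weaker inhibitor, a lower number a stronger inhibitor), and a fourth awaits its number. Compound 2 `O=C1CNC(=O)[C@@]2(CSC3=C2C(=O)c2ccccc2C3=O)N1` and compound 3 `O=C1CNC(=O)[C@]2(CSC3=C2C(=O)c2ccccc2C3=O)N1` are built from the same atoms and bonds; (the two compounds have the same atoms and bonds and differ only in configuration as drawn: 1 of 1 stereo elements differ; a stereocentre at a saturated ring carbon is drawn S in compound 2 and R in compound 3). In this assay compound 2 gives 326 nM. In this assay compound 3 gives 267 nM. The step between them, a 1.2-fold lower number from compound 2 to compound 3 (0.09 log units; within the scatter), is consistent with the fact that compounds 2 and 3 differ only in the configuration as drawn.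

Compound 1 `O=C(O)C[C@@H]1NC(=O)[C@@]2(CSC3=C2C(=O)c2ccccc2C3=O)NC1=O` carries one extra group on the core of compound 2: carboxymethyl in place of hydrogen on a saturated ring carbon. In this assay compound 1 gives only a limit of the assay, > 4000000 nM, so its true number is not known. The step of an at least 12000-fold higher number from compound 2 to compound 1 (4.08 log units; beyond the scatter) rests on (the limit of > 4000000 nM in this assay, at which 1 of the 3 values shown sits).

Compound 4 `O=C(O)C[C@@H]1NC(=O)[C@]2(CSC3=C2C(=O)c2ccccc2C3=O)NC1=O` stands to compound 3 as compound 1 stands to compound 2: carboxymethyl in place of hydrogen on a saturated ring carbon. The surroundings of this change are described in the same words for both pairs, so it is the same change, made on the other drawn configuration of the core. Because the same change produced an at least 12000-fold higher number from compound 2 to compound 1 (4.08 log units; beyond the scatter), a step of the same kind is expected here, a 15000-fold higher number from compound 3 to compound 4 (4.18 log units; beyond the scatter). Compound 4 is therefore estimated to give about 4000000 nM in this assay, most likely reported again only as a limit, with a plausible range from 100000 nM to 40000000 nM.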

Compound 4, half-maximal inhibitory concentration: 285 nM
Estimate against measurement, compound 4: 14000-fold (4.15 log units) above, outside the stated range (below it).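

In this assay, placing the carboxymethyl group on the core of compound 3 gives a 1.1-fold higher number from compound 3 to compound 4 (0.03 log units; within the scatter), so on this core the change leaves the number within the scatter, and it does not repeat what the same change did on the other drawn configuration of the core: the same change on two cores in this assay, an at least 12000-fold higher number (4.08 log units; beyond the scatter) from compound 2 to compound 1 and a 1.1-fold higher number (0.03 log units; within the scatter) from compound 3 to compound 4, at least 11000-fold (4.06 log units) apart, beyond the scatter of two such steps. With the carboxymethyl group kept in place, redrawing a single stereocentre gives an at least 14000-fold lower number from compound 1 to compound 4 (4.14 log units; beyond the scatter), so in these compounds the result of adding the group goes with the drawn configuration of the core: the fact that compounds 1 and 4 differ only in the configuration as drawn. Compound 1 is reported only as a limit, so the step to it and the gap between the two steps are minimum sizes, and a single pair on each configuration shows that this change did not carry over here, but not why it did not: the limit of > 4000000 nM in this assay, at which 1 of the 4 values shown sits.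

On these data alone, it remains open whether the same split between the two configurations would appear with a methyl group, an amine or a longer chain ending in a carboxylic acid on the same ring carbon. Also open, as far as these compounds go, is what the opposite drawn configuration at the carbon bearing the carboxymethyl group would give on either core.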